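The source may hold more compounds than are shown below. What is called first, only, known or untested is meant among the compounds shown, and "the series" means these compounds.

Compound 2 `Cc1ccccc1Cc1nc2cc(O[C@H]3CC[C@@H](C(=O)O)CC3)ccc2n1C` and compound 1 `Cc1cccc(Cc2cc3cc(O[C@H]4CC[C@@H](C(=O)O)CC4)ccc3n2C)c1` share a core but carry differently placed methylbenzyl groups. In an assay on isolated protein for inhibition of Long-chain-fatty-acid--CoA ligase 1 (Homo sapiens), read by mass spectrometry, with a stated time of 90 min, in the presence of a further agent that is not named here (on this read-out lower numbers stand for stronger inhibition and higher numbers for weaker inhibition), compound 1 gives 400 nM, while compound 2 gives 7800 nM, the higher of the two numbers and the weaker inhibition. Compound 3 `Cc1cccc(COc2nc3cc(O[C@H]4CC[C@@H](C(=O)O)CC4)ccc3n2C)c1` is not yet measured; it differs from compound 2 by (3-methylbenzyl)oxy in place of 2-methylbenzyl on an aromatic carbon. Within the data shown here, no direct step of this kind has been measured, so the expectation rests on compound 1, whose 400 nM suggests a meta-methyl can sit well. The step of a 3.9-fold lower number from compound 2 to compound 3 (0.59 log units; beyond the scatter) is therefore expected to lower the number, giving an estimated 2000 nM for compound 3, in a range from 500 nM to 8000 nM.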

Compound 3, half-maximal inhibitory concentration: 17000 nM
Beside the measured number, compound 3's estimate is 8.5-fold (0.93 log units) below it, and the stated range ends below it.
By their numbers in this assay, from the lowest: compound 1; then compound 2; then compound 3.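

In this assay, placing (3-methylbenzyl)oxy in place of 2-methylbenzyl on this aromatic carbon, between two ring nitrogen atoms, gives a 2.2-fold higher number from compound 2 to compound 3 (0.34 log units; beyond the scatter), a modest loss of inhibition. This one swap changes two things at once, adding an oxygen link and moving the methyl on the benzyl ring, and the two effects cannot be separated here. No measurement shown accounts for the loss. Still open, on these data alone, is how 3-methylbenzyl or (2-methylbenzyl)oxy would behave at this position, and whether a (3-methylbenzyl)amino group, with an amine nitrogen as the link, would match the oxygen-linked group.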